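Reversing the amide: from compound 1 to compound 3

The compounds below may be only part of what the source reports. "The series", "measured", "known", "first", "only" and "open" are said of these compounds alone.

Within the data shown here, compound 1 `COc1cc2oc(-c3cccc(NC(=O)c4ccc(Br)cc4)c3)cc(=O)c2c(OC)c1OC` gives 39.1% in a functional assay on Malme-3M cells (Homo sapiens) for inhibition, read by sulforhodamine B assay, tested at 10 uM (a lower number here means less inhibition, a higher number more inhibition at the concentration tested (going by the name of the read-out)), the lower of the two numbers measured so far; its only measured neighbour is compound 2 `COc1cc2oc(-c3cccc(NC(=O)c4ccc([N+](=O)[O-])cc4)c3)cc(=O)c2c(OC)c1OC`, which in this assay gives 70.2%. Among the measured compounds shown here, the single measured step, a number 31.1 percentage points higher from compound 1 to compound 2 (beyond the scatter), is nitro in place of bromo on an aromatic carbon. Compound 3 `COc1cc2oc(-c3cccc(C(=O)Nc4ccc(C)cc4)c3)cc(=O)c2c(OC)c1OC` carries a quite different change: (4-methylphenyl)carbamoyl in place of ((4-bromophenyl)carbonyl)amino on an aromatic carbon. For the measured compounds named here, no measured step bears on this change directly; the step from compound 1 to compound 2 shows only that altering the group on this aromatic carbon can move the read-out well beyond the scatter, and nothing in the data says which direction a reversed amide with a methyl would take. The estimate therefore stays near compound 1 with a wide range. Compound 3 is expected to give about 45%, between 15% and 80%, which corresponds to an expected step of a number 5.9 percentage points higher from compound 1 to compound 3 (within the scatter).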

Compound 3, a percentage reported as inhibition, at one concentration (the size of the read-out at that concentration, not a potency): 70.1%
The estimate for compound 3 lay 25.1 percentage points below the measured number; the range from low to high includes it.
By their numbers in this assay, from the lowest: compound 1; then compounds 3 and 2 (each within the scatter of the next).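

In this assay, the step is a number 31 percentage points higher from compound 1 to compound 3 (beyond the scatter), so this place responds strongly even to a swap that keeps the same number of heavy atoms, hydrogen-bond donors and hydrogen-bond acceptors. Alongside a number 31.1 percentage points higher from compound 1 to compound 2 (beyond the scatter), it is a second change within this side group that raises the number beyond the scatter. No measurement available here accounts for the size of this step.

The change reverses the amide and also puts methyl in place of bromo, so the compounds shown do not separate the part played by each. They also leave open how the reversed amide would respond to other groups on its outer ring, such as an amine or a carboxylic acid in place of the methyl.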